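Changing the amine on the side chain of compound 2

A few compounds are considered here, and "the series" means these few. Any claim that something is new, unique, unknown or untested is made for them only; others in the source may bear on it.

Measured compounds:
compound 1 `CCCN(CCC)CCNc1nnc(-c2ccccc2)cc1C` — 2 mg/kg
compound 2 `Cc1cc(-c2ccccc2)nnc1NCCCCN` — 0.1 mg/kg

Within the data shown here, in a functional assay on the whole organism with Mus musculus as the target (on this read-out higher numbers stand for an effect only at larger amounts of compound and lower numbers for an effect already at smaller amounts), compound 2 gives the lowest number of the two measured, with compound 1 giving 2 mg/kg as its only neighbour. The new compound 3 `Cc1cc(-c2ccccc2)nnc1NCCN(C)C` differs from compound 2 by dimethylamino in place of 2-aminoethyl on a saturated chain carbon, two bonds along the chain from a nitrogen on an aromatic ring. Among the measured compounds shown here, the one measured step that bears on this is a 20-fold lower number from compound 1 to compound 2 (1.30 log units; beyond the scatter), where a tertiary amine gave way to a primary amine on a longer chain. Compound 3 returns to a tertiary amine, so a move back toward compound 1 is expected, though smaller. For compound 3 the expected value is 0.6 mg/kg, within 0.15 mg/kg to 2.5 mg/kg, a step of a 6.0-fold higher number from compound 2 to compound 3 (0.78 log units; beyond the scatter).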

Compound 3, minimum effective dose: 10 mg/kg
Estimate against measurement, compound 3: 17-fold (1.22 log units) below, and the stated range ends below it.
By their numbers in this assay, from the lowest: compound 2; then compound 1; then compound 3.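

In this assay, among these compounds, the change at this position has a much larger effect than the earlier compounds suggested: a 100-fold higher number from compound 2 to compound 3 (2.00 log units; beyond the scatter). Among the tertiary amines, the smaller group does not bring the number down, with a 5.0-fold higher number from compound 1 to compound 3 (0.70 log units; beyond the scatter). Nothing available gives a reason for either step.

The compounds shown leave open whether the low number of compound 2 comes from its primary amine or from its longer chain. A primary amine on the shorter chain, or dimethylamino on the longer chain, would separate the two.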